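A few compounds are considered here, and "the series" means these few. Any claim that something is new, unique, unknown or untested is made for them only; others in the source may bear on it.

Measured so far in a physicochemical assay for lipophilicity, measured as octanol-water partition; a lower number here means a more polar compound, a higher number a more lipophilic compound:
- compound 1 `CC1=C(C(=O)OCc2cccnc2)C(c2cccc(O)c2)C2=C(CCCC2=O)N1`: 1.21
- compound 2 `COc1ccc(C2C(C(=O)OCc3cccnc3)=C(C)NC3=C2C(=O)CCC3)cc1`: 1.54
- compound 3 `CC1=C(C(=O)OCc2cccnc2)C(c2ccc([N+](=O)[O-])cc2)C2=C(CCCC2=O)N1`: 1.51

Compound 3, at 1.51, lies within the scatter of both other compounds, so the three numbers span a narrow range. The next compound is compound 4 `CC1=C(C(=O)OCc2cccnc2)C(c2cccs2)C2=C(CCCC2=O)N1`, and the change is thiophen-2-yl in place of 4-nitrophenyl on a saturated ring carbon.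

All three measured steps change the aryl group at this same carbon. The largest is a number 0.33 log units higher from compound 1 to compound 2 (beyond the scatter), and it is modest. Next comes a number 0.30 log units higher from compound 1 to compound 3 (within the scatter), while the step closest in kind to the new change among those leaving 3-hydroxyphenyl out is a number 0.03 log units lower from compound 2 to compound 3 (within the scatter). None of these steps brings in a five-membered aromatic ring, so they guide the estimate only loosely. In this assay, no shift beyond the scatter is expected. The expected step is a number 0.01 log units lower from compound 3 to compound 4 (within the scatter). For compound 4 the estimated value is 1.5, with an expected range from 1.2 to 1.8.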

Compound 4, partition coefficient: 1.4
The estimate for compound 4 lay 0.10 log units above the measured number; measured number inside the range.
By their numbers in this assay, from the lowest: compounds 1, 4, 3 and 2 (each within the scatter of the next, the first and the last beyond it).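

In this assay, thiophen-2-yl on this saturated ring carbon gives a number 0.11 log units lower from compound 3 to compound 4 (within the scatter), a number 0.14 log units lower from compound 2 to compound 4 (within the scatter) and a number 0.19 log units higher from compound 1 to compound 4 (within the scatter), so this first five-membered aromatic ring leaves no step beyond the scatter against any of the three six-membered aryl groups. Among these compounds, the exchange of 4-nitrophenyl, with 9 heavy atoms, for thiophen-2-yl, with 5 heavy atoms, therefore gives no clear shift at this position, and the only step beyond the scatter remains a number 0.33 log units higher from compound 1 to compound 2 (beyond the scatter). No measured evidence bears on this result.

Every compound shown keeps an aromatic ring at this carbon, so the effect of an open-chain alkyl group, an amine or a carboxylic acid here remains open. Changes to the ((pyridin-3-yl)methoxy)carbonyl group also remain open, as that group is the same throughout.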